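This account rests on a few compounds, and the source may have more. Where it says the series, first, only, none or still open, it means among the compounds named here.

Measured so far in a physicochemical assay for lipophilicity; a higher number here means a more lipophilic compound, a lower number a more polar compound:
compound 1 `O=C1CN(Cc2ccc(-c3ccc(F)c(CN4CCCCC4)n3)cc2)C(=O)N1CC1CC1`: 2.8
compound 2 `CCN1C(=O)CN(Cc2ccc(-c3cccc(CN4CCCCC4)n3)cc2)C1=O`: 1.7
compound 3 `CC(C)CN1C(=O)CN(Cc2ccc(-c3ccc(F)c(CN4CCCCC4)n3)cc2)C1=O`: 3.4

Of these three, compound 3 stands highest, at 3.4. Compound 4 `CCN1C(=O)CN(Cc2ccc(-c3ccc(F)c(CN4CCCCC4)n3)cc2)C1=O` differs from it in one place, with methyl in place of isopropyl on a saturated chain carbon bound to an amide-type nitrogen in a ring. The same difference reads isobutyl to ethyl. Going by the values given here, one measured step bears directly on this change, and it is modest: a number 0.60 log units higher from compound 1 to compound 3 (beyond the scatter). Compound 2 also carries the ethyl, but on a different core, and compound 2 gives 1.7. In this assay, a fall somewhat larger than that step and beyond the scatter is expected: a number 1.10 log units lower from compound 3 to compound 4 (beyond the scatter). For compound 4 the estimated value is 2.3, with an expected range from 1.9 to 2.7.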

Compound 4, distribution coefficient: 2.1
The estimate for compound 4 lay 0.20 log units above the measured number, within the range that was stated.
By their numbers in this assay, from the lowest: compound 2; then compound 4; then compound 1; then compound 3.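

In this assay, going by these compounds alone, this position proves more responsive than the one earlier step showed: isobutyl to ethyl gives a number 1.30 log units lower from compound 3 to compound 4 (beyond the scatter), and methyl in place of cyclopropyl gives a number 0.70 log units lower from compound 1 to compound 4 (beyond the scatter). Separately, fluoro in place of hydrogen on an aromatic carbon, with the ethyl held fixed, gives a number 0.40 log units higher from compound 2 to compound 4 (beyond the scatter). No measurement at hand accounts for these shifts. The compounds shown leave open whether this order among the groups would extend to a longer chain, or to a chain ending in an amine.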